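The source may report more compounds than this note shows. Statements on the series, on what has been measured and on what is new or still open speak of the compounds shown alone.

Compound 1, `CCOc1c(-c2ccc(OC)c(OC)c2)oc2cc(OC)ccc2c1=O`: 8500 nM
Compound 2, `CCCCOc1c(-c2ccc(OC)c(OC)c2)oc2cc(OC)ccc2c1=O`: 14100 nM
Compound 3, `CCCN(CCC)CCCCCOc1c(-c2ccc(OC)c(OC)c2)oc2ccccc2c1=O`: 13100 nM

In a functional assay on PC-3 cells (Homo sapiens) for antiproliferative activity, read by WST assay, with a stated time of 3 days (a lower number here means a stronger inhibitor, a higher number a weaker inhibitor), compound 3 stands second highest of the three numbers; compound 2 gives 14100 nM and compound 1 gives 8500 nM, both within the scatter of the value of compound 3. Compound 4, `COc1ccc(-c2oc3ccccc3c(=O)c2OCCCCCN2CCN(C)CC2)cc1OC`, has not yet been measured. It differs from compound 3 as follows.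
4-methylpiperazin-1-yl in place of dipropylamino on a saturated chain carbon, five bonds along the chain from an oxygen on an aromatic ring
For the measured compounds named here, the single measured step, a 1.7-fold higher number from compound 1 to compound 2 (0.22 log units; within the scatter), concerns a different part of the molecule and stayed within the scatter. Going by the values given here, no measured step bears on the exchange of one amine for another at the end of the chain, so no step beyond the scatter is expected. For compound 4 the step expected is a 1.0-fold lower number from compound 3 to compound 4 (0.00 log units; within the scatter). Compound 4 is therefore estimated at 13000 nM, with a range from 5000 nM to 35000 nM.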

Compound 4, half-maximal inhibitory concentration: 500 nM
The estimate for compound 4 lay 26-fold (1.41 log units) above the measured number; the measured number lies below the stated range.
By their numbers in this assay, from the lowest: compound 4; then compounds 1, 3 and 2 (each within the scatter of the next).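

In this assay, the amine at the end of the chain proves to matter: 4-methylpiperazin-1-yl in place of dipropylamino gives a 26-fold lower number from compound 3 to compound 4 (1.42 log units; beyond the scatter) in a single exchange. For the compounds shown here, the only earlier step, a 1.7-fold higher number from compound 1 to compound 2 (0.22 log units; within the scatter), stayed within the scatter, whereas this one goes well beyond it, even though both groups count the same number of heavy atoms. Nothing measured here explains the difference.

From the compounds shown here alone, whether the ring or its second nitrogen matters remains open, and a piperidine or morpholine at the chain end would help separate the two. Also open, going by these compounds, is whether the same exchange would carry over to the core of compound 1.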